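This account rests on a few compounds, and the source may have more. Where it says the series, first, only, none or still open, it means among the compounds named here.

Working notes on the series. Compound 1 `C=CC(=O)Nc1ccc(-c2nc(Cl)cc(Nc3ccc(C(=O)Nc4ccc(OC)cc4)cc3)n2)cc1` carries the shared core with a (4-methoxyphenyl)carbamoyl group; in a functional assay on Raji cells (Homo sapiens) for antiproliferative activity, read by MTT assay, with a stated time of 48 h (a higher number here means a weaker inhibitor, a lower number a stronger inhibitor), compound 1 gives "not determined" (no result reported), so no single number places it on the scale. Among the measured compounds shown here, the one measured member is compound 2 `C=CC(=O)Nc1ccc(-c2nc(Cl)cc(Nc3ccc(C(=O)Nc4cc(C(F)(F)F)cc(C(F)(F)F)c4)cc3)n2)cc1`, which differs from compound 1 in the amide substituent, and in this assay compound 2 gives 9360 nM, a weak result.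

The step of interest leads to compound 3 `C=CC(=O)Nc1ccc(-c2nc(Cl)cc(Nc3ccc(C(=O)N(C)C)cc3)n2)cc1`. The change from compound 1 is dimethylamino in place of (4-methoxyphenyl)amino on a carbonyl carbon. With no number for compound 1 in this assay, neither the size nor the direction of this step can be read from the series itself; the only anchor is the weak figure of compound 2.

On that anchor alone, compound 3 is expected to land in the same weak region, with an estimated value of 8000 nM in this assay, the plausible range running from 2000 nM to 30000 nM. The measurement will decide.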

Compound 3, half-maximal inhibitory concentration: 42900 nM
Beside the measured number, compound 3's estimate is 5.4-fold (0.73 log units) below it; measured number above the stated range.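

No step can be read from the new result: in this assay compound 3 gives 42900 nM, while compound 1 gives "not determined" (no result reported). The compounds shown leave open how the change from (4-methoxyphenyl)carbamoyl to dimethylcarbamoyl acts on the core of compound 1. No evidence bearing on this result is available.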